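Methyl for Methoxy on a Fluorophenyl Ring

This account rests on a few compounds, and the source may have more. Where it says the series, first, only, none or still open, it means among the compounds named here.

Of the compounds shown here, two from one series have been measured in an ADME assay on microsomes from liver (Homo sapiens) for metabolic stability; on this read-out lower numbers stand for slow clearance and higher numbers for fast clearance. Compound 1, `COc1cc([C@](O)(CCN(C)C)[C@@H](c2cc3cc(C#N)ccc3nc2OC)c2cccc(C)c2F)cc(OC(F)F)n1`, gives 0.6 uL/min in this assay. Compound 2, `CCSc1cc([C@](O)(CCN(C)C)[C@@H](c2cc3cc(C#N)ccc3nc2OC)c2cccc(OC)c2F)cc(SCC)n1`, gives 17 uL/min in this assay. Compound 2 therefore has the highest of the two numbers, and its nearest neighbour, compound 1, stands a long way below it, well beyond the usual scatter. Among the compounds with values here, the two compounds differ in several places at once, so no single step between them can be read off.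

The next compound, compound 3, is `CCSc1cc([C@](O)(CCN(C)C)[C@@H](c2cc3cc(C#N)ccc3nc2OC)c2cccc(C)c2F)cc(SCC)n1`. Compound 3 is compound 2 with one change: methyl in place of methoxy on an aromatic carbon. Compound 1 carries the same methyl on that ring, but its other differences from compound 2 are too many to let its value guide the expectation for compound 3 with any confidence.

Within the data shown here, with no direct step in this assay to lean on, a modest move toward slower clearance is expected, of the size given by a 1.5-fold lower number from compound 2 to compound 3 (0.19 log units; within the scatter), which may well stay within the scatter. Compound 3 is therefore estimated to give 11 uL/min in this assay, with a likely range from 4 uL/min to 30 uL/min.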

Compound 3, intrinsic clearance in a liver preparation (reported as CLH), per the amount of preparation that the assay uses: 9.1 uL/min
For compound 3 the middle estimate is 1.2-fold (0.08 log units) above the measured one, within the range that was stated.
By their numbers in this assay, from the lowest: compound 1; then compounds 3 and 2 (each within the scatter of the next).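

In this assay, within the data shown here, methyl in place of methoxy on this carbon of the fluorophenyl ring gives a 1.9-fold lower number from compound 2 to compound 3 (0.27 log units; within the scatter) and this is the first direct reading at this position: the change leaves no difference that can be told apart from the ordinary spread of repeat measurements. With the same 2-fluoro-3-methylphenyl group on both compounds, the sulfur-bearing group of compound 3 in place of the oxygen- and fluorine-bearing group of compound 1 gives a 15-fold higher number from compound 1 to compound 3 (1.18 log units; beyond the scatter) and so, among these three compounds, the large gap in this assay goes with that other group and not with the methyl or methoxy on the fluorophenyl ring. No measurement shown here explains the size of either step.

Going by these compounds, what a chloro or an ethyl group would give at this same position remains open, as does whether swapping methyl for methoxy would read the same with the group of compound 1 in place. On these data alone, it also remains open which part of the larger group goes with the gap, for instance whether replacing only one of its two ethylthio groups with a methoxy group would account for it.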